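The source may hold more compounds than are shown below. What is called first, only, known or untested is meant among the compounds shown, and "the series" means these compounds.

Compound 1, `O=C(CCCCCCn1cc(Nc2ncc3ccn(Cc4ccccc4F)c3n2)cn1)NO`, gives 8.4 nM in an assay on isolated protein for inhibition of protein deacetylase HDAC6 (Homo sapiens), with a stated time of 60 min; on this read-out lower numbers stand for stronger inhibition and higher numbers for weaker inhibition. Compound 2, `O=C(CCCCCCn1cc(Nc2ncc3ccn(Cc4ccccc4Cl)c3n2)cn1)NO`, gives 41.5 nM in this assay. Compound 3, `O=C(CCCCCCn1cc(Nc2ncc3ccn(C4CCCC4)c3n2)cn1)NO`, gives 22 nM in this assay.

Among these three numbers compound 3 holds the second highest. Its nearest neighbour is compound 2, separated by a 1.9-fold lower number from compound 2 to compound 3 (0.28 log units; within the scatter), and its furthest is compound 1, separated by a 2.6-fold higher number from compound 1 to compound 3 (0.42 log units; beyond the scatter). Compound 4, `O=C(CCCCCCn1cc(Nc2ncc3ccn(CC4CCCCC4)c3n2)cn1)NO`, has not yet been measured in this assay. It differs from compound 3 in one place: cyclohexylmethyl in place of cyclopentyl on an aromatic nitrogen.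

Within the data shown here, two measured steps touch the same aromatic nitrogen. The change from 2-fluorobenzyl to cyclopentyl gave a 2.6-fold higher number from compound 1 to compound 3 (0.42 log units; beyond the scatter), a modest weakening, while the change from 2-chlorobenzyl to cyclopentyl gave a 1.9-fold lower number from compound 2 to compound 3 (0.28 log units; within the scatter). Among the measured compounds shown here, no measured step exchanges one saturated carbocycle for another, so the expectation for compound 4 is modest: a step of about a 1.1-fold lower number from compound 3 to compound 4 (0.04 log units; within the scatter) is estimated, with no strong lean in either direction. Compound 4 is therefore expected to give roughly 20 nM in this assay, within a range of 8 nM to 55 nM.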

Compound 4, half-maximal inhibitory concentration: 88 nM
For compound 4 the middle estimate is 4.4-fold (0.64 log units) below the measured one; measured number above the stated range.
By their numbers in this assay, from the lowest: compound 1; then compounds 3 and 2 (each within the scatter of the next); then compound 4.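

Cyclohexylmethyl in place of cyclopentyl gave a 4.0-fold higher number from compound 3 to compound 4 (0.60 log units; beyond the scatter) in this assay, so on this aromatic nitrogen one saturated carbocycle cannot simply stand in for another, even though neither group carries a hydrogen-bond donor or acceptor. Against the benzyl groups, cyclohexyl in place of 2-chlorophenyl on the saturated chain carbon gave a 2.1-fold higher number from compound 2 to compound 4 (0.33 log units; beyond the scatter) and cyclohexyl in place of 2-fluorophenyl gave a 10-fold higher number from compound 1 to compound 4 (1.02 log units; beyond the scatter), which leaves compound 4 the weakest of the four. Nothing measured here explains these steps.

The compounds shown leave open whether the weakening follows the six-membered ring or the chain carbon that carries it, a question that cyclohexyl on the aromatic nitrogen or cyclopentylmethyl would separate. Going by these compounds, how an unsubstituted benzyl or a piperidinylmethyl, which brings an amine into the ring, would stand also remains open.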